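Alpha-methylation in a biphenyl ether keto-tetrazole series

The compounds below may be only part of what the source reports. "The series", "measured", "known", "first", "only" and "open" are said of these compounds alone.

Measured compounds and values:
compound 1 `O=C(COc1ccc(-c2ccccc2)cc1)Cn1cnnn1`: 43 nM
compound 2 `CC(C(=O)COc1ccc(-c2ccccc2)cc1)n1cnnn1`: > 10000 nM
compound 3 `CC(C(=O)COc1ccc(-c2ccccc2)cc1)n1ncnn1`: 6300 nM

In an assay on microsomes from brain for inhibition of Fatty-acid amide hydrolase 1 (Rattus norvegicus), read by fluorescence and HPLC, with a stated time of 60 min (a lower number here means a stronger inhibitor, a higher number a weaker inhibitor), compound 1 gives 43 nM, the lowest number among the values shown. Compound 2 returns only a limit here, (the limit of > 10000 nM in this assay, at which 1 of the 3 values shown sits). Compound 3 gives 6300 nM in this assay. Both measured methyl steps, an at least 230-fold higher number from compound 1 to compound 2 (2.36 log units; beyond the scatter) and a 150-fold higher number from compound 1 to compound 3 (2.17 log units; beyond the scatter), fall on the saturated chain carbon bound to an aromatic nitrogen and a carbonyl carbon; the change of tetrazole attachment, an at least 1.5-fold lower number from compound 2 to compound 3 (0.20 log units; that floor lies within the scatter), is small.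

Compound 4 `CC(Oc1ccc(-c2ccccc2)cc1)C(=O)Cn1cnnn1` carries the change (methyl in place of hydrogen on a saturated chain carbon bound to a carbonyl carbon and an oxygen on an aromatic ring). Among the measured compounds shown here, no measured step touches this carbon, so the large losses seen on the tetrazole-bearing carbon guide only loosely. A clear but smaller rise in number is expected, a 7.0-fold higher number from compound 1 to compound 4 (0.84 log units; beyond the scatter). Compound 4 is estimated at 300 nM in this assay, within 50 nM to 3000 nM.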

Compound 4, half-maximal inhibitory concentration: 19 nM
Beside the measured number, compound 4's estimate is 16-fold (1.20 log units) above it; the whole stated range lies above it.
By their numbers in this assay, from the lowest: compound 4; then compound 1; then compound 3. At a limit, above all of these: compound 2.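

In this assay, methyl in place of hydrogen on the saturated chain carbon bound to a carbonyl carbon and an oxygen on an aromatic ring brings a gain, with a 2.3-fold lower number from compound 1 to compound 4 (0.35 log units; beyond the scatter), not a loss. Methyl on the carbon bound to the tetrazole gave large rises in number, so the outcome of this change in the series depends on which carbon carries it. Nothing shown accounts for the contrast between the two carbons.

Open, on these data alone, is whether an ethyl group, a longer chain or a hydroxymethyl group on this carbon keeps the number low. Also open, as far as these compounds go, is whether a second methyl on the same carbon does so.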